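Fluoro on the benzyl group of compound 2

A few compounds are considered here, and "the series" means these few. Any claim that something is new, unique, unknown or untested is made for them only; others in the source may bear on it.

Two compounds of the series carry measurements in a functional assay on MKN-45 cells (Homo sapiens) for cytotoxicity, read by MTT assay, with a stated time of 48 h; on this read-out lower numbers stand for stronger inhibition and higher numbers for weaker inhibition. Compound 1 `COc1cc(-c2nnc(SC)n2/N=C/c2ccccc2)cc(OC)c1OC`, with a methylsulfanyl group on the shared core, gives 28500 nM. Compound 2 `COc1cc(-c2nnc(SCc3ccccc3)n2/N=C/c2ccccc2)cc(OC)c1OC` carries a benzyl group on the sulfur instead. In this assay compound 2 reaches only the limit of the assay, > 200000 nM, so its value is a limit and not a number (the limit of > 200000 nM in this assay, at which 1 of the 2 values shown sits). The step of an at least 7.0-fold higher number from compound 1 to compound 2 (0.84 log units; beyond the scatter) is therefore only a lower bound on the loss. Compound 3 `COc1cc(-c2nnc(SCc3ccc(F)cc3)n2/N=C/c2ccccc2)cc(OC)c1OC` is still to be measured. It differs from compound 2 by fluoro in place of hydrogen on an aromatic carbon. Among the compounds with values here, no measured step touches such a substitution on the benzyl ring; the only measured step, an at least 7.0-fold higher number from compound 1 to compound 2 (0.84 log units; beyond the scatter), concerns the entry of the phenyl itself and ends at the limit. Compound 2 already stands at the upper edge of the numbers shown, so compound 3 is expected to stay in that region. The estimated step of a number no higher from compound 2 to compound 3 (the limit leaves the size open) is accordingly expected to be none beyond the scatter. Compound 3 is estimated at 200000 nM, with a range from 60000 nM to 600000 nM, and a real chance of again only a limit.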

Compound 3, half-maximal inhibitory concentration: > 200000 nM
Compound 3: only a limit was reported; the forecaster's own chance of this, stated with the estimate: 65%; the middle value lies on the limit itself.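

Compound 3 gives > 200000 nM in this assay and this value is a limit of the assay and not a number. The step of an at least 7.0-fold higher number from compound 1 to compound 3 (0.84 log units; beyond the scatter) is a second lower bound, so the loss relative to the methylsulfanyl group now appears with the 4-fluorobenzyl group as well as with the plain benzyl group on the sulfur. The steps between the two limits cannot be read, so whether fluoro in place of hydrogen on the benzyl ring changes anything at this position remains unresolved, and the series has no measured number on the benzyl side of the sulfur: the limit of > 200000 nM in this assay, at which 2 of the 3 values shown sit.

From the compounds shown here alone, what lies between the methylsulfanyl and benzyl groups remains open, for example whether an ethyl group or a longer saturated chain on the sulfur keeps a value below the limit or moves it to the limit. Going by these compounds, it is equally open whether an amine or a carboxylic acid on the benzyl ring would bring a compound of this type back to a measurable number in this assay and so make a ring substitution readable at all.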